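The source may report more compounds than this note shows. Statements on the series, on what has been measured and on what is new or still open speak of the compounds shown alone.

Of the compounds shown here, three sharing one core have been tested in an ADME assay on MT4 cells (Homo sapiens) for cytotoxicity, read by MTT assay, with a stated time of 96 h; on this read-out higher numbers stand for lower toxicity in this test and lower numbers for higher toxicity in this test: compound 1 (`CC(=O)Oc1ccc2ccc(=O)oc2c1Cc1c(C)[nH]c2ccccc12`), compound 2 (`CC(=O)Oc1ccc2c(C)cc(=O)oc2c1Cc1c(-c2ccccc2)[nH]c2ccccc12`) and compound 3 (`CC(=O)Oc1ccc2c(C)cc(=O)oc2c1Cc1c[nH]c2ccccc12`). In this assay compound 3 gives 100000 nM, and compound 1 gives 62000 nM, so these two numbers lie within the scatter of each other. Compound 2 reads > 100000 nM, which is a limit of the assay and not a number. Compound 2 thus stands at the limit of > 100000 nM in this assay, at which 1 of the 3 values shown sits.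

Compound 4 (`CC(=O)Oc1ccc2c(C)cc(=O)oc2c1Cc1c(C)[nH]c2ccccc12`) differs from compound 3 in one place: methyl in place of hydrogen on an aromatic carbon. This is methyl in place of hydrogen on an aromatic carbon, on a five-membered aromatic ring with 1 nitrogen, next to the ring nitrogen. Within the data shown here, the only measured step at this carbon is a number no higher from compound 2 to compound 3 (the limit leaves the size open), hydrogen in place of phenyl on an aromatic carbon, and its size cannot be read. It therefore gives no measured size for the new change. With compound 3 at 100000 nM and compound 1 at 62000 nM, the numbers shown give no sign of a large move, so no change beyond the scatter is expected in this assay. The expected step is a 1.3-fold lower number from compound 3 to compound 4 (0.10 log units; within the scatter), a slight drop that stays within the scatter. For compound 4 the estimated value is 80000 nM, with an expected range of 40000 nM to 160000 nM.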

Compound 4, half-maximal cytotoxic concentration: 41000 nM
Compound 4: middle estimate off by 2.0-fold (0.29 log units), on the high side; the measured number falls inside the stated range.
By their numbers in this assay, from the lowest: compounds 4, 1 and 3 (each within the scatter of the next, the first and the last beyond it).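

In this assay, among these compounds, the exchange at the aromatic carbon next to the ring nitrogen now has a readable size, a 2.4-fold lower number from compound 3 to compound 4 (0.39 log units; beyond the scatter), a modest step beyond the scatter, whereas the only earlier step at this carbon could not be read. The same kind of exchange, methyl in place of hydrogen, at another carbon of the shared core gives a 1.5-fold lower number from compound 1 to compound 4 (0.18 log units; within the scatter), which stays within the scatter, so among these compounds only the change on the five-membered ring moves the number beyond the scatter. Methyl in place of phenyl at the first carbon gives an at least 2.4-fold lower number from compound 2 to compound 4 (0.38 log units; beyond the scatter), but the size of this step stays open, as compound 2 reads as a limit of the assay and not a number: the limit of > 100000 nM in this assay, at which 1 of the 4 values shown sits.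

The compounds shown carry only hydrogen, methyl and phenyl at this carbon, so how an ethyl group, a chlorine atom or an amine there would read remains open. From the compounds shown here alone, it also remains open whether the step from hydrogen to methyl at this carbon would have the same size on the core of compound 1.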